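Series notes: cytotoxicity step from compound 2 to compound 4

A few compounds are considered here, and "the series" means these few. Any claim that something is new, unique, unknown or untested is made for them only; others in the source may bear on it.

Three compounds share a core and have been run in an ADME assay on HepG2 cells (Homo sapiens) for cytotoxicity, read by luminescence, CellTiter-Glo and ATP content, with a stated time of 72 h; a higher number here means that more compound is needed for the effect, a lower number that less compound is needed. Compound 1 `COc1ccc(F)cc1CNCCCNc1ccnc2cc(Cc3ccc(C#N)cc3)ccc12` gives 6050 nM. Compound 3 `COc1ccc(F)cc1CNCCCNc1ccnc2cc(Oc3cccc(N(C)C)c3)ccc12` gives 3300 nM; the step of a 1.8-fold lower number from compound 1 to compound 3 (0.26 log units; within the scatter) is within the scatter. Compound 2 `FC(F)(F)c1ccc(-c2ccc3c(NCCCNCc4ccco4)ccnc3c2)cc1` gives 3470 nM, the second highest of the three numbers, within the scatter of compound 3 and of compound 1. Compound 4 `Fc1ccc(Cc2ccc3c(NCCCNCc4ccco4)ccnc3c2)c(Cl)c1` is not yet measured; it differs from compound 2 as follows: 2-chloro-4-fluorobenzyl in place of 4-(trifluoromethyl)phenyl on an aromatic carbon. Within the data shown here, no measured step bears directly on this change, and the one step recorded, a 1.8-fold lower number from compound 1 to compound 3 (0.26 log units; within the scatter), was within the scatter. The step of a 1.2-fold higher number from compound 2 to compound 4 (0.06 log units; within the scatter) is therefore expected to stay within the scatter. For compound 4 in this assay the estimate is 4000 nM, expected to lie between 1500 nM and 11000 nM.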

Compound 4, half-maximal effective concentration: 5730 nM
Estimate against measurement, compound 4: 1.4-fold (0.16 log units) below; the range from low to high includes it.
By their numbers in this assay, from the lowest: compounds 3, 2, 4 and 1 (each within the scatter of the next).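

In this assay, the exchange of 4-(trifluoromethyl)phenyl for 2-chloro-4-fluorobenzyl gives a 1.7-fold higher number from compound 2 to compound 4 (0.22 log units; within the scatter), so a second pair of compounds now shows a change on this aromatic carbon staying within the scatter. This pair carries a different side chain from the pair formed by compound 1 and compound 3, and it tests a benzyl group against a phenyl group directly. No supporting measurement offers an explanation for this step. Still open, going by these compounds, is whether an amine, a carboxylic acid or a longer chain on this aromatic carbon would move the number beyond the scatter.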